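Hydrazone aryl replacement: 3-chloro-4-fluorophenyl to 2-chlorophenyl

A few compounds are considered here, and "the series" means these few. Any claim that something is new, unique, unknown or untested is made for them only; others in the source may bear on it.

Measured so far in a functional assay on A549 cells (Homo sapiens) for antiproliferative activity, read by MTT assay; a higher number here means a weaker inhibitor, a lower number a stronger inhibitor:
- compound 1, `Cn1c(=O)c(=O)n(C2CCCC2)c2nc(N/N=C/c3ccc(O)cc3)ncc21`; for compound 1 the assay reports only a limit, > 100000 nM
- compound 2, `Cn1c(=O)c(=O)n(C2CCCC2)c2nc(N/N=C/c3ccc(F)c(Cl)c3)ncc21`; compound 2 gives 9410 nM

Going by the values given here, compound 2 holds the only real number; the other entry is a limit (the limit of > 100000 nM in this assay, at which 1 of the 2 values shown sits). Among the compounds with values here, the one measured step, an at least 10-fold lower number from compound 1 to compound 2 (1.02 log units; beyond the scatter), shows that a halogenated aryl on the hydrazone carbon is markedly more potent than the hydroxyphenyl, but it compares with compound 1 and says nothing about moving between two halogenated aryls.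

Compound 3, `Cn1c(=O)c(=O)n(C2CCCC2)c2nc(N/N=C/c3ccccc3Cl)ncc21`, differs from compound 2 by 2-chlorophenyl in place of 3-chloro-4-fluorophenyl on a carbon with a double bond to nitrogen. Within the data shown here, no measured step bears directly on this change, so no step beyond the scatter is expected in this assay in either direction; a 1.3-fold higher number from compound 2 to compound 3 (0.11 log units; within the scatter) is the estimated step. Compound 3 is expected at 12000 nM, between 4000 nM and 40000 nM.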

Compound 3, half-maximal inhibitory concentration: 9860 nM
Beside the measured number, compound 3's estimate is 1.2-fold (0.09 log units) above it; measured number inside the range.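

In this assay, the exchange of one chlorinated aryl for another is a 1.0-fold higher number from compound 2 to compound 3 (0.02 log units; within the scatter), so 2-chlorophenyl and 3-chloro-4-fluorophenyl cannot be told apart on this carbon with a double bond to nitrogen. Replacing 4-hydroxyphenyl with 2-chlorophenyl gives an at least 10-fold lower number from compound 1 to compound 3 (1.00 log units; beyond the scatter), so the advantage over 4-hydroxyphenyl now rests on two different chlorinated aryls rather than one. The value for compound 1 is a limit, so the full size of both steps from it cannot be read: the limit of > 100000 nM in this assay, at which 1 of the 3 values shown sits.

Going by these compounds, it remains open whether the chlorine itself matters, since unsubstituted phenyl, or a ring carrying a methoxy group, a dimethylamino group or a carboxylic acid, could fall with compound 2 and compound 3 or with compound 1. Also open, on these data alone, is whether any group at this position gives a number beyond the scatter of those two compounds.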